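The source may hold more compounds than are shown below. What is called first, only, known or untested is meant among the compounds shown, and "the series" means these compounds.

Series notes. The shared core is shown by compound 1 `CC(C)(C)OC(=O)NCCCCNC(=O)CN1CN(c2ccccc2)C2(CCN(C(=O)c3ccc(C(C)(C)C)cc3)CC2)C1=O`, and in an assay on HEK293 cells for displacement of a labelled ligand from NPC1-like intracellular cholesterol transporter 1 (Homo sapiens) (a lower number here means a stronger inhibitor, a higher number a weaker inhibitor), compound 1 gives "not determined" (no result reported). Among the measured compounds shown here, compound 2 `CC(C)(C)c1ccc(C(=O)N2CCC3(CC2)C(=O)N(CC(=O)NCCCCCNS(C)(=O)=O)CN3c2ccccc2)cc1` gives 5500 nM in this assay, and compound 3 `CCOC(=O)C1CCCN(C(=O)CN2CN(c3ccccc3)C3(CCN(C(=O)c4ccc(C5CCCCC5)cc4)CC3)C2=O)C1` gives 4200 nM in this assay; the two values lie within the usual scatter of each other, so neither is set apart, and with only two numbers there is no wider context for compound 2.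

Compound 4 `CC(C)(C)c1ccc(C(=O)N2CCC3(CC2)C(=O)N(CC(=O)N2CCCC(C(N)=O)C2)CN3c2ccccc2)cc1` has not been measured. It differs from compound 2 in one place: 3-carbamoylpiperidin-1-yl in place of (5-(methanesulfonamido)pentyl)amino on a carbonyl carbon. For the measured compounds named here, no two measured compounds differ in a single place, so the effect of this change cannot be read from a measured step. Compound 3 also carries a piperidine ring on a carbonyl carbon, though it differs from compound 2 elsewhere as well, and compound 3 gives 4200 nM, near compound 2.

The expected change is therefore estimated at a 1.2-fold lower number from compound 2 to compound 4 (0.09 log units; within the scatter), which is no larger than the scatter. Compound 4 is estimated at 4500 nM in this assay, with a range from 1500 nM to 14000 nM.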

Compound 4, half-maximal inhibitory concentration: 16900 nM
For compound 4 the middle estimate is 3.8-fold (0.57 log units) below the measured one; measured number outside the range, above it.
By their numbers in this assay, from the lowest: compounds 3 and 2 (each within the scatter of the next); then compound 4.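

In this assay, among the compounds shown here, 3-carbamoylpiperidin-1-yl in place of (5-(methanesulfonamido)pentyl)amino on a carbonyl carbon gives a 3.1-fold higher number from compound 2 to compound 4 (0.49 log units; beyond the scatter), the first step that changes a single place. This position is therefore not indifferent to the group it carries: the open chain and the substituted ring are not interchangeable here, although the step is only modest. Nothing at hand explains the step.

On these data alone, the ring and its carbamoyl group enter together, so their separate contributions stay open; an unsubstituted piperidin-1-yl or a piperidine bearing a carboxylic acid would help to separate them. Also open, as far as these compounds go, is how the chain itself reads in this assay when shortened or ended in a free amine.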